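The compounds below may be only part of what the source reports. "The series", "measured", "known", "first", "only" and "open" are said of these compounds alone.

Measured so far in an ADME assay on S9 fraction from liver (Rattus norvegicus) for metabolic stability, read by LC-MS, using NADPH, with a stated time of 30 min; a lower number here means that less of the compound is left, a higher number that more of the compound is left:
- compound 1 `CCCCCCCCc1ccc(OCC(=O)Cn2nnc(C)n2)cc1`: < 5%, a limit of the assay and not a number
- compound 2 `CCCCCCCCc1ccc(OCC(=O)Cn2nnc(-c3ccc(Cl)cc3)n2)cc1`: 74%
- compound 3 `CCCCCCCCc1ccc(OCC(=O)Cn2nnc(-c3ccc(C(=O)OC)cc3)n2)cc1`: 64%

Among the compounds with values here, compound 3 stands level with the only other compound that gives a number, and the two are not separated: a number 10 percentage points lower from compound 2 to compound 3 (within the scatter).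

The next change leads to compound 4 `CCCCCCCCc1ccc(OCC(=O)Cn2nnc(-c3cccc(S(=O)(=O)N(C)C)c3)n2)cc1`: 3-(dimethylsulfamoyl)phenyl in place of 4-(methoxycarbonyl)phenyl on an aromatic carbon of the five-membered aromatic ring with 4 nitrogen (3-(dimethylsulfamoyl)phenyl in place of 4-(methoxycarbonyl)phenyl on an aromatic carbon).

Two large steps came from replacing methyl with a substituted phenyl at this same place: a number at least 69 percentage points higher from compound 1 to compound 2 (beyond the scatter) and a number at least 59 percentage points higher from compound 1 to compound 3 (beyond the scatter). Both start from a limit: the limit of < 5% in this assay, at which 1 of the 3 values shown sits. Compound 4 keeps a substituted phenyl there, so neither large step is expected to be undone. The step that changed only the substituent on the phenyl stayed within the scatter, as shown above. Within the data shown here, no measured compound carries the dimethylsulfamoyl group, so this single comparison is a thin guide and the range is kept wide.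

In this assay, no change beyond the scatter is expected, starting from compound 3 at 64%. The expected step is a number 2 percentage points lower from compound 3 to compound 4 (within the scatter). The estimated value for compound 4 is 62%, with an expected range from 40% to 82%.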

Compound 4, percent of the compound remaining: 9%
The estimate for compound 4 lay 53 percentage points above the measured number; the whole stated range lies above it.
By their numbers in this assay, from the lowest: compound 4; then compounds 3 and 2 (each within the scatter of the next). At a limit, below all of these: compound 1.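

In this assay, a substituted phenyl on the aromatic carbon of the five-membered aromatic ring with 4 nitrogen does not by itself secure a high read-out: a number 55 percentage points lower from compound 3 to compound 4 (beyond the scatter), and a number 65 percentage points lower from compound 2 to compound 4 (beyond the scatter). Within the data shown here, the earlier exchange of one substituent on the phenyl stayed within the scatter, so these are the first steps to show that the choice of substituted phenyl at this place can matter as much as the step away from methyl. Measured against the methyl compound, the new group gives only a floor that cannot be told from the scatter: a number at least 4 percentage points higher from compound 1 to compound 4 (that floor lies within the scatter).

Compound 1 gives a limit of the assay and not a number, and this leaves that last step without a size: the limit of < 5% in this assay, at which 1 of the 4 values shown sits.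

Because 3-(dimethylsulfamoyl)phenyl differs from both earlier aryl groups in the substituent and in where it sits on the phenyl, the compounds shown cannot separate the two, and a 4-(dimethylsulfamoyl)phenyl or a 3-(methoxycarbonyl)phenyl would be needed to do so. From the compounds shown here alone, how an unsubstituted sulfamoyl group, an amide or a carboxylic acid on this phenyl would read also remains open.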